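This account rests on a few compounds, and the source may have more. Where it says the series, first, only, none or still open, it means among the compounds named here.

Measured so far in the series:

compound 1 `Cn1ncc(Cl)c1-c1cc(C(=O)N[C@H]2CNCC[C@@H]2c2ccc(C(F)(F)F)cc2)oc1Cl` — 127 nM
compound 2 `Cn1ncc(Cl)c1-c1cc(C(=O)N[C@@H]2CN[C@H](CC(=O)NC3CC3)C[C@H]2c2ccc(Cl)c(Cl)c2)oc1Cl` — 3.95 nM
compound 3 `CC(=O)OCC[C@@H]1C[C@@H](c2ccc(F)c(F)c2)[C@H](NC(=O)c2cc(-c3c(Cl)cnn3C)c(Cl)o2)CN1` — 3.4 nM

In an assay for inhibition of RAC-alpha serine/threonine-protein kinase (Homo sapiens), read by HTRF, with a stated time of 1 h (a lower number here means a stronger inhibitor, a higher number a weaker inhibitor), compound 2 gives 3.95 nM, the second highest of the three numbers. Nearest to it is compound 3 with 3.4 nM, a gap that lies within the scatter, so no order between compound 2 and compound 3 can be read from these two values. Furthest is compound 1 with 127 nM, a gap beyond the scatter. Among the compounds with values here, compound 1 carries no substituent on the saturated ring beyond the aryl group, whereas compound 2 and compound 3 each carry an additional side chain; no single-change pair among the measured compounds isolates that point.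

Compound 4 `Cn1ncc(Cl)c1-c1cc(C(=O)N[C@@H]2CN[C@H](CC(N)=O)C[C@H]2c2ccc(Cl)c(Cl)c2)oc1Cl` differs from compound 2 in one place: hydrogen in place of cyclopropyl on an amide-type nitrogen. The change sits at the far end of the side chain, away from the shared core. Within the data shown here, no measured pair shows this change, so no measured step is available for it. The expected step is a 1.3-fold higher number from compound 2 to compound 4 (0.10 log units; within the scatter), a small shift in either direction and none beyond the scatter. Compound 4 is estimated at 5 nM, with a range from 2 nM to 15 nM.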

Compound 4, half-maximal inhibitory concentration: 3.24 nM
For compound 4 the middle estimate is 1.5-fold (0.19 log units) above the measured one, within the range that was stated.
By their numbers in this assay, from the lowest: compounds 4, 3 and 2 (each within the scatter of the next); then compound 1.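

In this assay, within the data shown here, hydrogen in place of cyclopropyl on the amide-type nitrogen gives a 1.2-fold lower number from compound 2 to compound 4 (0.09 log units; within the scatter), the first single-change step. At this far end of the side chain, the two values cannot be told apart, so the cyclopropyl group is not required to keep a number of this size in this pair. No measured evidence bears on why the two values match.

Still open, from the compounds shown here alone, is how a larger group on this nitrogen, such as a longer alkyl chain or a phenyl ring, would read, and whether a carboxylic acid or an amine could stand in place of the carbamoyl group. Also open, going by these compounds, is the result of replacing the whole carbamoylmethyl group with hydrogen while the rest of compound 4 stays the same.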